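Second Chloro Group on a Cytotoxic Hybrid Series

A few compounds are considered here, and "the series" means these few. Any claim that something is new, unique, unknown or untested is made for them only; others in the source may bear on it.

Compound 1 `O=C(CCCCC1CCSS1)NCc1cn(CCCOc2ccc3cc(-c4ccccc4)c(=O)oc3c2)nn1` gives 23.1% in a functional assay on PC-12 cells (Rattus norvegicus) for cytotoxicity, read by MTT assay, with stated times of 3 h and 2 h, tested at 50 uM; a lower number here means a weaker effect, a higher number a stronger effect of the compound at the concentration tested. Compound 2 `O=C(CCCCC1CCSS1)NCc1cn(CCCOc2ccc3cc(-c4ccc(Cl)cc4)c(=O)oc3c2)nn1` differs from it by chloro in place of hydrogen on an aromatic carbon, and in this assay compound 2 gives 79.4%, so that this change made a number 56.3 percentage points higher from compound 1 to compound 2 (beyond the scatter). Compound 3 `O=C(CCCCC1CCSS1)NCc1cn(CCCCOc2ccc3cc(-c4ccc(Cl)cc4)c(=O)oc3c2)nn1` carries the same chloro group, but its core differs from that of compound 1 in a way that is not broken down here; in this assay compound 3 gives 74.9%, a number within the scatter of that of compound 2. Compound 4 `O=C(CCCCC1CCSS1)NCc1cn(CCCCOc2ccc3cc(-c4ccc(Cl)c(Cl)c4)c(=O)oc3c2)nn1` has not yet been measured. It differs from compound 3 by chloro in place of hydrogen on an aromatic carbon. This is the same kind of change as from compound 1 to compound 2, but not the same: there the entering group sat para to a large group, here it sits ortho to a chloro group and meta to a large group. Because compound 3 already gives 74.9%, and compound 2 with one chloro group gives 79.4%, the account expects only a modest step of a number 5.1 percentage points higher from compound 3 to compound 4 (within the scatter), far smaller than a number 56.3 percentage points higher from compound 1 to compound 2 (beyond the scatter). Compound 4 is expected to give 80%, between 62% and 93%.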

Compound 4, a percentage reported as activity, at one concentration (the size of the read-out at that concentration, not a potency): 69.5%
Compound 4: middle estimate off by 10.5 percentage points, on the high side; low and high end bracket the measured number.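

In this assay, the second chloro group gave a number 5.4 percentage points lower from compound 3 to compound 4 (within the scatter), so the 3,4-dichlorophenyl compound cannot be told apart from the 4-chlorophenyl compound that precedes it. The same change therefore does not carry over from one core to the other with the same size, and the two steps differ: the same change on two cores in this assay, a number 56.3 percentage points higher (beyond the scatter) from compound 1 to compound 2 and a number 5.4 percentage points lower (within the scatter) from compound 3 to compound 4, 61.7 percentage points apart, beyond the scatter of two such steps This does not show what sets the two steps apart, as the two pairs differ in their core and also in where the chloro group enters, and two pairs make no rule for the series.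

The compounds shown leave open what a fluoro or methoxy group or an amine would do in place of the new chloro group on this six-membered aromatic ring. They also leave open whether a longer chain would change the picture, and the read-out, taken at a single concentration, gives no potency for any of these compounds.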